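Adding a second chlorine to the aryl ring

A few compounds are considered here, and "the series" means these few. Any claim that something is new, unique, unknown or untested is made for them only; others in the source may bear on it.

Compound 2 `C=CCn1c(=O)/c(=C\c2ccccc2Cl)[nH]c(=O)/c1=C\c1ccccc1OC` and compound 1 `C=CCn1c(=O)/c(=C\c2cccc(F)c2)[nH]c(=O)/c1=C\c1ccccc1OC` share one core and differ only in the halogenated phenyl ring on the double-bonded chain carbon. In a functional assay on K562 cells (Homo sapiens) for cytotoxicity, read by CCK-8 assay, with a stated time of 72 h (a lower number here means a stronger inhibitor, a higher number a weaker inhibitor), compound 1 gives 4100 nM, and compound 2 gives 2500 nM. Within the data shown here, the step of a 1.6-fold lower number from compound 1 to compound 2 (0.21 log units; within the scatter) is the only comparison so far, and it lies within the scatter, so the two numbers cannot be told apart with confidence. Compound 3 `C=CCn1c(=O)/c(=C\c2cccc(Cl)c2Cl)[nH]c(=O)/c1=C\c1ccccc1OC` keeps the frame of compound 2 and changes one place: chloro in place of hydrogen on an aromatic carbon. Among the measured compounds shown here, no measured step introduces a second halogen on this ring, and the one step that alters the halogen pattern, from compound 1 to compound 2, stayed within the scatter. A step of similar size is therefore expected, giving for compound 3 an estimate of 2000 nM, with a range from 800 nM to 5000 nM, corresponding to an expected step of a 1.3-fold lower number from compound 2 to compound 3 (0.10 log units; within the scatter).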

Compound 3, half-maximal inhibitory concentration: 900 nM
Estimate against measurement, compound 3: 2.2-fold (0.35 log units) above; the measured number falls inside the stated range.
By their numbers in this assay, from the lowest: compound 3; then compounds 2 and 1 (each within the scatter of the next).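

In this assay, adding chloro to the ring of compound 2 to give the 2,3-dichlorophenyl group brings a 2.8-fold lower number from compound 2 to compound 3 (0.44 log units; beyond the scatter), a step beyond the scatter, which the earlier pair did not provide. This shows that the aromatic carbon ortho to the existing chloro group is a place where replacing hydrogen can change the number measurably. Compared with the 3-fluorophenyl ring, the 2,3-dichlorophenyl ring gives a 4.6-fold lower number from compound 1 to compound 3 (0.66 log units; beyond the scatter), so compound 3 stands apart from both earlier compounds, even though those two remain within the scatter of each other. No evidence is available to explain this gain.

The compounds shown leave open whether chloro is specifically needed at this carbon, or whether bromo, methyl or an amine there would give a similar step.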